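Amide nitrogen variation in one series

The source may report more compounds than this note shows. Statements on the series, on what has been measured and on what is new or still open speak of the compounds shown alone.

Measured in a functional assay on MCF7 cells (Homo sapiens) for inhibition, read by MTT assay, with a stated time of 48 h; on this read-out higher numbers stand for weaker inhibition and lower numbers for stronger inhibition:
compound 1 `COc1ccc(/C=C/c2cc(OC)cc(OC)c2/C=C/C(=O)NC2CC2)cc1`: 3940 nM
compound 2 `C#CCNC(=O)/C=C/c1c(/C=C/c2ccc(OC)cc2)cc(OC)cc1OC`: 4560 nM
compound 3 `CCCCN(CCCC)C(=O)/C=C/c1c(/C=C/c2ccc(OC)cc2)cc(OC)cc1OC`: 3990 nM

Compound 1 stands lowest of the three numbers in this assay, but the others sit right beside it: the step of a 1.2-fold higher number from compound 1 to compound 2 (0.06 log units; within the scatter) and the step of a 1.0-fold higher number from compound 1 to compound 3 (0.01 log units; within the scatter) are both within the scatter, as is the step of a 1.1-fold lower number from compound 2 to compound 3 (0.06 log units; within the scatter). On these numbers nothing separates the three substituents on the amide-type nitrogen from one another.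

Compound 4 `COc1ccc(/C=C/c2cc(OC)cc(OC)c2/C=C/C(=O)NC(C)C)cc1` differs from compound 1 in one place: isopropyl in place of cyclopropyl on an amide-type nitrogen. The measured steps that bear on this change are the ones that also exchange the group on the amide-type nitrogen, a 1.2-fold higher number from compound 1 to compound 2 (0.06 log units; within the scatter), a 1.0-fold higher number from compound 1 to compound 3 (0.01 log units; within the scatter) and a 1.1-fold lower number from compound 2 to compound 3 (0.06 log units; within the scatter), and none of them moves the number beyond the scatter. Cyclopropyl, propargyl and dibutylamino return the same number in this assay, and nothing among the three measured compounds suggests that isopropyl would read otherwise. The expected step of a 1.0-fold higher number from compound 1 to compound 4 (0.01 log units; within the scatter) is therefore of no size beyond the scatter. Compound 4 is estimated at 4000 nM in this assay, with a range from 2000 nM to 8000 nM.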

Compound 4, half-maximal inhibitory concentration: 2560 nM
The estimate for compound 4 lay 1.6-fold (0.19 log units) above the measured number, and the stated range covers the measured number.
By their numbers in this assay, from the lowest: compounds 4, 1, 3 and 2 (each within the scatter of the next).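

Isopropyl in place of cyclopropyl removes the three-membered ring at this position while keeping the same count of heavy atoms, and this assay shows a 1.5-fold lower number from compound 1 to compound 4 (0.19 log units; within the scatter) as the size of that exchange, so a ring on the amide-type nitrogen is not required for a number in this range. The two wider exchanges, a 1.6-fold lower number from compound 3 to compound 4 (0.19 log units; within the scatter) and a 1.8-fold lower number from compound 2 to compound 4 (0.25 log units; within the scatter), also stay inside the scatter, so the series now holds four groups on this nitrogen, branched, cyclic, propargyl and dibutyl, that this assay does not separate. Nothing measured here accounts for the differences that do appear among these four numbers, small as they are.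

Still open, on these data alone, is whether any group on this nitrogen can move the number beyond the scatter at all, for instance a longer chain ending in an amine or a carboxylic acid, or a phenyl or benzyl group. The compounds shown also leave the shared core unchanged, so they cannot say whether the methoxy groups or the ethenyl linkers carry more weight in this assay than the amide does.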